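From 3-cyanophenyl to 4-methoxyphenyl on the shared core

The source may hold more compounds than are shown below. What is called first, only, known or untested is meant among the compounds shown, and "the series" means these compounds.

Compound 1 `C=CC(=O)Nc1cccc(Oc2nc(Nc3ccn(C)n3)nc3c2CSCC3)c1`: > 50000 nM
Compound 2 `C=CC(=O)Nc1cccc(Oc2nc(Nc3cccc(OC)c3)nc3c2CSCC3)c1`: 48900 nM
Compound 3 `C=CC(=O)Nc1cccc(Oc2nc(Nc3cccc(C#N)c3)nc3c2CSCC3)c1`: > 50000 nM

In an ADME assay on L02 cells (Homo sapiens) for cytotoxicity, read by MTT assay, with a stated time of 72 h (a higher number here means a weaker inhibitor, a lower number a stronger inhibitor), compound 3 has only a limit, > 50000 nM, and not a number. The set crowds at the limit of > 50000 nM in this assay, at which 2 of the 3 values shown sit.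

Compound 4 `C=CC(=O)Nc1cccc(Oc2nc(Nc3ccc(OC)cc3)nc3c2CSCC3)c1` has 4-methoxyphenyl in place of 3-cyanophenyl on a nitrogen on an aromatic ring.

Among the measured compounds shown here, two measured steps bear on this change: an at least 1.0-fold lower number from compound 1 to compound 2 (0.00 log units; that floor lies within the scatter), and an at least 1.0-fold higher number from compound 2 to compound 3 (0.00 log units; that floor lies within the scatter). Neither shows a change beyond the scatter, and compound 2, with its 3-methoxyphenyl, gives 48900 nM. For the measured compounds named here, the expected size is an at least 1.0-fold lower number from compound 3 to compound 4 (0.01 log units; that floor lies within the scatter), with no step expected beyond the scatter. For compound 4 the estimated value is 48000 nM, within an expected range of 28000 nM to 80000 nM.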

Compound 4, half-maximal inhibitory concentration: > 50000 nM
Compound 4: no number, only a limit; the forecaster's own chance of this, stated with the estimate: 55%; at least 1.0-fold (0.01 log units) between middle value and limit.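

In this assay, compound 4 gives only a limit, > 50000 nM, and not a number. Putting 4-methoxyphenyl in place of 3-methoxyphenyl gives an at least 1.0-fold higher number from compound 2 to compound 4 (0.00 log units; that floor lies within the scatter), so this change on the nitrogen shows nothing beyond the scatter, while the steps linking compound 4 with compound 1 and compound 3 cannot be read. The set now gathers even more tightly at one value: the limit of > 50000 nM in this assay, at which 3 of the 4 values shown sit.

From the compounds shown here alone, whether an amine or a carboxylic acid on this phenyl ring would give a readable number stays open. Going by these compounds, how far compound 1, compound 3 and compound 4 lie past their limits also stays unknown.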